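The source may report more compounds than this note shows. Statements on the series, on what has been measured and on what is new or still open speak of the compounds shown alone.

Compound 1 `CCCCCCNc1nc(SCc2ccc(C(F)(F)F)cc2)nc2ccccc12` is the point of departure. In a functional assay on PC-3 cells (Homo sapiens) for cytotoxicity, read by MTT assay, with a stated time of 72 h (a higher number here means a weaker inhibitor, a lower number a stronger inhibitor), compound 1 gives 19000 nM, the second highest of the three numbers in hand; compound 2 `FC(F)(F)c1ccc(CSc2nc(Nc3ccccc3Cl)c3ccccc3n2)cc1` gives 20400 nM and compound 3 `COc1ccccc1Nc1nc(SCc2ccc(C(F)(F)F)cc2)nc2ccccc12` gives 14100 nM, all within the scatter of one another. Compound 4 `FC(F)(F)c1ccc(CSc2nc(Nc3cccc(C(F)(F)F)c3)c3ccccc3n2)cc1` differs from compound 1 in one place: 3-(trifluoromethyl)phenyl in place of hexyl on a nitrogen on an aromatic ring. Going by the values given here, the steps that bear on it are a 1.1-fold higher number from compound 1 to compound 2 (0.03 log units; within the scatter) and a 1.3-fold lower number from compound 1 to compound 3 (0.13 log units; within the scatter), each a substituted phenyl in place of hexyl on the same nitrogen, neither beyond the scatter. A third aryl in that position is therefore expected to give a 1.1-fold lower number from compound 1 to compound 4 (0.05 log units; within the scatter), nothing beyond the scatter. Compound 4 is estimated at 17000 nM, between 8000 nM and 38000 nM.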

Compound 4, half-maximal inhibitory concentration: 12900 nM
Compound 4: the middle estimate sits 1.3-fold (0.12 log units) above what was measured; the range from low to high includes it.
By their numbers in this assay, from the lowest: compounds 4, 3, 1 and 2 (each within the scatter of the next).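

In this assay, going by these compounds alone, a third aryl on this nitrogen gives a 1.5-fold lower number from compound 1 to compound 4 (0.17 log units; within the scatter) and exchanges among the aryl groups give a 1.1-fold lower number from compound 3 to compound 4 (0.04 log units; within the scatter) and a 1.6-fold lower number from compound 2 to compound 4 (0.20 log units; within the scatter) so that no step yet separates any of these groups. 3-(Trifluoromethyl)phenyl therefore reads the same as hexyl, 2-chlorophenyl and 2-methoxyphenyl at this position. No evidence at hand explains this flat response.

On these data alone, whether an amine-bearing chain, a carboxylic acid or a morpholine ring on this nitrogen would move the number beyond the scatter remains open. So does the effect of any change elsewhere on the shared core.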